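Urea series: aryl swap on the ring nitrogen

The source may hold more compounds than are shown below. What is called first, only, known or untested is meant among the compounds shown, and "the series" means these compounds.

Measured so far:
compound 1 `CC(C)c1cccc(C(C)C)c1NC(=O)Nc1nc2ccccc2n1-c1cccc(Cl)c1` — 20 nM
compound 2 `CC(C)c1cccc(C(C)C)c1NC(=O)Nc1nc2ccccc2n1-c1c(Cl)cccc1Cl` — 11 nM

Among the measured compounds shown here, in an assay on isolated protein for displacement of a labelled ligand from acyl-CoA:cholesterol acyltransferase (Oryctolagus cuniculus) (a higher number here means a weaker inhibitor, a lower number a stronger inhibitor), compound 1 gives 20 nM, the highest of the two numbers; the single step, a 1.8-fold lower number from compound 1 to compound 2 (0.26 log units; within the scatter), stays within the scatter. Compound 3 `CC(C)c1cccc(C(C)C)c1NC(=O)Nc1nc2ccccc2n1-c1ccccc1O` differs from compound 1 by 2-hydroxyphenyl in place of 3-chlorophenyl on an aromatic nitrogen. For the measured compounds named here, no measured step covers a 2-hydroxyphenyl entering in this place, and the only step on record is flat, so no change beyond the scatter is expected in this assay, with some room for a weaker number. Compound 3 is estimated at 30 nM, between 10 nM and 100 nM, an expected step of a 1.5-fold higher number from compound 1 to compound 3 (0.18 log units; within the scatter).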

Compound 3, half-maximal inhibitory concentration: 200 nM
The estimate for compound 3 lay 6.7-fold (0.82 log units) below the measured number; the whole stated range lies below it.
By their numbers in this assay, from the lowest: compounds 2 and 1 (each within the scatter of the next); then compound 3.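

In this assay the aryl group on this aromatic nitrogen turns out not to be interchangeable, which the two chlorophenyl compounds did not show: 2-hydroxyphenyl gives a 10-fold higher number from compound 1 to compound 3 (1.00 log units; beyond the scatter) and an 18-fold higher number from compound 2 to compound 3 (1.26 log units; beyond the scatter). Both steps lie beyond the scatter. No measurement at hand accounts for this loss.

From the compounds shown here alone, whether the loss goes with the hydroxyl itself or with the absence of chlorine remains open. Going by these compounds, how a methoxy group or an amine on that phenyl ring would read is also open.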